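The compounds below may be only part of what the source reports. "The series", "measured", "known", "first", "only" and "open" are said of these compounds alone.

Working notes on the series. In an ADME assay on microsomes from liver (Homo sapiens) for metabolic stability, read by LC-MS, using NADPH, with a stated time of 30 min, tested at 1 uM (a higher number here means faster removal of the compound, a lower number slower removal), compound 1 `CC#Cc1cncc(-c2ccc3c(c2)[C@@]2(COC(N)=N2)c2cc(-c4ccnc(F)c4)ncc2O3)c1` gives 40 mL.min-1.g-1, the lower of the two numbers at hand. Compound 2 `NC1=N[C@@]2(CO1)c1cc(-c3cncc(C#CC4CC4)c3)ccc1Oc1cnc(C3=CCOCC3)cc12` gives 80 mL.min-1.g-1 in this assay, a value that sits within the scatter of that for compound 1, so the two are not separated by this measurement. Compound 3 `CC#Cc1cncc(-c2ccc3c(c2)[C@@]2(COC(N)=N2)c2cc(Cl)ncc2O3)c1` has not yet been measured in this assay. Its structure differs from that of compound 1 in one place: chloro in place of 2-fluoropyridin-4-yl on an aromatic carbon. Within the data shown here, no measured pair in the set shows this change, so its size cannot be read from the data. Given only the values of compound 1 and compound 2, a step in either direction that stays within the scatter is the most that can be expected for this assay. Compound 3 is therefore estimated at 50 mL.min-1.g-1, with a range from 20 mL.min-1.g-1 to 120 mL.min-1.g-1, which means an expected step of a 1.3-fold higher number from compound 1 to compound 3 (0.10 log units; within the scatter).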

Compound 3, intrinsic clearance in microsomes: 27 mL.min-1.g-1
Compound 3: the middle estimate sits 1.9-fold (0.27 log units) above what was measured; measured number inside the range.
By their numbers in this assay, from the lowest: compounds 3, 1 and 2 (each within the scatter of the next, the first and the last beyond it).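

Among these compounds, at this aromatic carbon next to the ring nitrogen, chloro in place of 2-fluoropyridin-4-yl provides the first single-place comparison, and in this assay it gives a 1.5-fold lower number from compound 1 to compound 3 (0.17 log units; within the scatter). This step lies within the scatter, so removing the whole six-membered aromatic ring and leaving a single chlorine atom at this position produces no separable difference in this measurement. Nothing at hand explains why the two values stay within the scatter of each other.

As far as these compounds go, how an amine, a methoxy group or a carboxylic acid at this position would read in this assay remains open. Also open, from the compounds shown here alone, is whether the step from 2-fluoropyridin-4-yl to chloro would keep its size with a different group elsewhere on the shared core.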